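A few compounds are considered here, and "the series" means these few. Any claim that something is new, unique, unknown or untested is made for them only; others in the source may bear on it.

Measured compounds and their numbers:

Compound 1, `COc1ccc(-c2cc3ccccc3nc2C=O)cc1`: in a functional assay on H184B5F5/M10 cells (Homo sapiens) for antiproliferative activity, read by XTT assay, with a stated time of 72 h (on this read-out higher numbers stand for weaker inhibition and lower numbers for stronger inhibition), compound 1 gives > 10000 nM, which is a limit of the assay and not a number.
Compound 2, `COc1ccc(-c2cc3ccccc3nc2/C=C/C(=O)c2ccccc2)cc1`: compound 2 gives 8560 nM.
Compound 3, `COc1ccc(-c2cc3ccccc3nc2/C=C/C(=O)c2ccc(OC)cc2OC)cc1`: compound 3 gives 6110 nM.

Compound 3 holds the lowest of the two numbers shown, and its nearest neighbour is compound 2; the step of a 1.4-fold lower number from compound 2 to compound 3 (0.15 log units; within the scatter) lies within the scatter, so no order between the two can be claimed. Compound 1 stands at the limit of > 10000 nM in this assay, at which 1 of the 3 values shown sits.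

Compound 4, `COc1ccc(-c2cc3ccccc3nc2/C=C/C(=O)c2ccc([N+](=O)[O-])cc2)cc1`, has not yet been measured in this assay. It differs from compound 3 in one place: 4-nitrophenyl in place of 2,4-dimethoxyphenyl on a carbonyl carbon. For the measured compounds named here, the only measured step touching the same carbonyl carbon is a 1.4-fold lower number from compound 2 to compound 3 (0.15 log units; within the scatter), and it stayed within the scatter. Because a 1.4-fold lower number from compound 2 to compound 3 (0.15 log units; within the scatter) moved the number so little, the account expects the step to compound 4 to stay within the scatter as well, and the expected step is a 1.1-fold higher number from compound 3 to compound 4 (0.06 log units; within the scatter). Compound 4 is therefore estimated at 7000 nM, with a range from 2500 nM to 20000 nM.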

Compound 4, half-maximal inhibitory concentration: 6100 nM
For compound 4 the middle estimate is 1.1-fold (0.06 log units) above the measured one, within the range that was stated.
By their numbers in this assay, from the lowest: compounds 4, 3 and 2 (each within the scatter of the next). At a limit, above all of these: compound 1.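

At the carbonyl carbon, the change to 4-nitrophenyl gives a 1.0-fold lower number from compound 3 to compound 4 (0.00 log units; within the scatter), and the comparison with the unsubstituted phenyl gives a 1.4-fold lower number from compound 2 to compound 4 (0.15 log units; within the scatter). Both steps stay within the scatter in this assay, so adding nitro at this aryl group shifts the number no more than the two methoxy groups did. Compounds 2, 3 and 4 therefore form a set of three differently substituted aryl groups whose numbers cannot be put in any order, and none of the three goes against this.

The compounds shown leave open whether an amine or a carboxylic acid on this aryl ring, or a simple alkyl chain in its place on the carbonyl carbon, would move the number beyond the scatter. Nothing measured among these compounds bears on what lies behind these closely matched numbers.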